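The source may hold more compounds than are shown below. What is called first, only, known or untested is meant among the compounds shown, and "the series" means these compounds.

Measured so far:
compound 1, `CCN(Cc1ccccc1C(F)(F)F)C(=O)C1CCN(S(=O)(=O)c2ccc3[nH]ncc3c2)CC1`, 96%
compound 2, `C=CCN(Cc1ccccc1C(F)(F)F)C(=O)C1CCN(S(=O)(=O)c2ccc3[nH]ncc3c2)CC1`, 79%

In a functional assay on CHO cells for positive allosteric modulation of muscarinic acetylcholine receptor M5 (Homo sapiens), read by calcium flux (on this read-out lower numbers stand for smaller maximal responses and higher numbers for larger maximal responses), compound 2 stands lowest of the two numbers; its nearest neighbour is compound 1, and the step of a number 17 percentage points lower from compound 1 to compound 2 (beyond the scatter) lies beyond the scatter. Compound 3, `CC(C)N(Cc1ccccc1C(F)(F)F)C(=O)C1CCN(S(=O)(=O)c2ccc3[nH]ncc3c2)CC1`, differs from compound 2 by isopropyl in place of allyl on an amide-type nitrogen. Within the data shown here, no measured step swaps allyl for isopropyl, so only the single step from compound 1 to compound 2 gives a hint of how changes on this nitrogen move the largest response, and it was modest. Compound 3 is therefore expected near compound 2, with a number 8 percentage points higher from compound 2 to compound 3 (within the scatter), estimated at 87% within 68% to 104%.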

Compound 3, largest response reached (reported as percent of maximum), in percent of the reference or control that the assay uses: 54%
For compound 3 the middle estimate is 33 percentage points above the measured one; measured number below the stated range.
By their numbers in this assay, from the lowest: compound 3; then compound 2; then compound 1.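

In this assay, allyl and isopropyl each carry 3 heavy atoms, yet they are not interchangeable on this amide-type nitrogen: the swap gives a number 25 percentage points lower from compound 2 to compound 3 (beyond the scatter). Adding one methyl to the saturated chain carbon bound to that nitrogen has a larger outcome, with a number 42 percentage points lower from compound 1 to compound 3 (beyond the scatter), so the response depends strongly on this single branching change. Nothing measured here explains the fall. On these data alone, it remains open how a longer unbranched chain such as propyl, a cyclopropyl group or a plain hydrogen on this nitrogen would behave.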